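A Methyl for a Fluoro on the Shared Core

A few compounds are considered here, and "the series" means these few. Any claim that something is new, unique, unknown or untested is made for them only; others in the source may bear on it.

Compound 1 `O=C1CC2(CO1)CSC(=S)N2c1ccc(F)cc1` was examined in a functional assay on EC9706 cells (Homo sapiens) for antiproliferative activity, read by MTT assay, with a stated time of 72 h; on this read-out higher numbers stand for weaker inhibition and lower numbers for stronger inhibition. In this assay compound 1 gives > 50 ug/mL, which is a limit of the assay rather than a number. Compound 2 `O=C1CC2(CO1)CSC(=S)N2Cc1ccccc1` carries a different group on the shared core. In this assay compound 2 gives > 50 ug/mL, again a limit and not a number. Among the measured compounds shown here, compound 1 thus stands at the limit of > 50 ug/mL in this assay, at which 2 of the 2 values shown sit, and no step between measured compounds can be drawn from these data. Compound 3 `Cc1ccc(N2C(=S)SCC23COC(=O)C3)cc1` differs from compound 1 by methyl in place of fluoro on an aromatic carbon. With the measured compounds at the limit, no direction can be read, and the step that the limit leaves unreadable from compound 1 to compound 3 is expected to be none beyond the scatter. Compound 3 is expected to give about 70 ug/mL in this assay, within 30 ug/mL to 200 ug/mL, most likely reported once more as a limit.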

Compound 3, half-maximal inhibitory concentration: > 50 ug/mL
Compound 3: no number, only a limit (the forecaster's own chance of this, stated with the estimate: 80%); the middle value lies beyond the limit too.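

Compound 3, like compound 1, stands at a limit and not a number in this assay, so no step can be read for methyl in place of fluoro between them: the limit of > 50 ug/mL in this assay, at which 3 of the 3 values shown sit. The compounds shown leave open how far past that limit each lies, and whether any group on the shared core gives a readable number.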